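The compounds below may be only part of what the source reports. "The series", "measured", "known", "first", "only" and "open" are said of these compounds alone.

Measured in a functional assay on HCT-116 cells (Homo sapiens) for antiproliferative activity, read by WST assay, with a stated time of 72 h; a lower number here means that less compound is needed, a higher number that more compound is needed for the effect:
compound 1 `CCCCNCCCCC(=O)Nc1ccc(/C(N)=N/O)cc1`: 516000 nM
compound 2 `CCCCCCNCC(=O)Nc1ccc(/C(N)=N/O)cc1`: 124000 nM
compound 3 `CCCCNCC(=O)Nc1ccc(/C(N)=N/O)cc1`: 83000 nM

Compound 3 shares the low end of these numbers with one other compound: a 1.5-fold lower number from compound 2 to compound 3 (0.17 log units; within the scatter). Compound 1 needs clearly more than both.

Compound 4 `CCCCNCCC(=O)Nc1ccc(/C(N)=N/O)cc1` differs from compound 3 by one change: (butylamino)methyl in place of butylamino on a saturated chain carbon bound to a carbonyl carbon. Here (butylamino)methyl stands in place of butylamino on a saturated chain carbon bound to a carbonyl carbon.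

Among the compounds with values here, no measured step makes this exact change. The only one, a 1.5-fold lower number from compound 2 to compound 3 (0.17 log units; within the scatter), concerns an ethyl group elsewhere on the chain and says little here. Chain length offers a better guide. Compound 3 gives 83000 nM, while compound 1, with a longer chain leading to the carbonyl, gives 516000 nM. The chain of compound 4 is longer than that of compound 3 and shorter than that of compound 1, so a small rise in this assay is expected, probably within the scatter. The expected change is a 1.7-fold higher number from compound 3 to compound 4 (0.23 log units; within the scatter). For compound 4 the estimate is 140000 nM, with an expected range of 70000 nM to 300000 nM.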

Compound 4, half-maximal effective concentration: 153000 nM
Compound 4: the middle estimate sits 1.1-fold (0.04 log units) below what was measured; the range from low to high includes it.
By their numbers in this assay, from the lowest: compounds 3, 2 and 4 (each within the scatter of the next); then compound 1.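

In this assay, the step from butylamino to (butylamino)methyl on a saturated chain carbon bound to a carbonyl carbon gives a 1.8-fold higher number from compound 3 to compound 4 (0.27 log units; within the scatter), so this small extension leaves compound 4 not clearly separated from compound 3. The comparison with hexylamino at the same place gives a 1.2-fold higher number from compound 2 to compound 4 (0.09 log units; within the scatter), so that exchange does not separate the two compounds either. The first clear difference at this place appears with the larger 2-(butylamino)ethyl, where butylamino in its place gives a 3.4-fold lower number from compound 1 to compound 4 (0.53 log units; beyond the scatter), showing that this position tolerates some extension of the chain but not all of it.

No data here give a reason for these differences. On these data alone, it also remains open how a carboxylic acid or a piperidine ring at this place would behave.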